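The source may hold more compounds than are shown below. What is called first, only, known or untested is meant among the compounds shown, and "the series" means these compounds.

Compound 1 `Cc1cc(C)c(CN2CCc3c(Cl)cc([C@@H](CO)[C@@H]4CCCO4)c(Cl)c3C2=O)c(=O)[nH]1` and compound 3 `Cc1cc(C)c(CN2CCc3c(Cl)cc([C@@H](CO)[C@H]4CCCO4)c(Cl)c3C2=O)c(=O)[nH]1` share all atoms and bonds and differ only in the configuration drawn at one stereocentre of the saturated ring. Among the compounds with values here, in a functional assay on KARPAS-422 cells (Homo sapiens) for antiproliferative activity, read by resazurin assay, with a stated time of 72 h (a higher number here means a weaker inhibitor, a lower number a stronger inhibitor), compound 1 gives 1220 nM, and compound 3 gives 535 nM; the step of a 2.3-fold lower number from compound 1 to compound 3 (0.36 log units; beyond the scatter) is the only measured comparison in the set, and with the reason for it resting solely on the fact that compounds 1 and 3 differ only in the configuration as drawn it shows that a change in configuration alone can move the number beyond the scatter. Compound 2 `COC(c1cc(Cl)c2c(c1Cl)C(=O)N(Cc1c(C)cc(C)[nH]c1=O)CC2)C1CCOCC1` carries a six-membered ring in place of the five-membered one and gives 1150 nM; 19 nM (2 entries) in this assay, two entries far apart that do not settle into a single number (the several entries of compound 2 in this assay, 1150 nM; 19 nM (2 entries)). Among the single numbers, compound 3 stands lowest, with compound 1 as its only neighbour.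

Compound 4 `Cc1cc(C)c(CN2CCc3c(Cl)cc([C@H](CO)[C@H]4CCOC4)c(Cl)c3C2=O)c(=O)[nH]1` is the next step from compound 3: a group of 8 heavy atoms (6 carbon, 2 oxygen; one five-membered non-aromatic ring with 1 hetero atom) in place of a group of 8 heavy atoms (6 carbon, 2 oxygen; one five-membered non-aromatic ring with 1 hetero atom), on an aromatic carbon. The same atoms are joined differently, with the saturated ring attached through a different ring carbon and both stereocentres redrawn. The nearest measured precedent is a 2.3-fold lower number from compound 1 to compound 3 (0.36 log units; beyond the scatter), a modest shift from a configurational change; a rearrangement of this size is expected to give a step of comparable magnitude in this assay, with no secure direction. The expected step is a 1.4-fold higher number from compound 3 to compound 4 (0.15 log units; within the scatter), giving for compound 4 an estimate of 750 nM, within 200 nM to 2800 nM.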

Compound 4, half-maximal inhibitory concentration: 15 nM
Estimate against measurement, compound 4: 50-fold (1.70 log units) above, and the stated range ends above it.
By their numbers in this assay, from the lowest: compound 4; then compound 3; then compound 1.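

At the aromatic carbon ortho to a chloro group, the leaving and entering groups have the same counts of heavy atoms, donors and acceptors, yet the result in this assay is a 36-fold lower number from compound 3 to compound 4 (1.55 log units; beyond the scatter), so these counts alone do not set the number. Set against a 2.3-fold lower number from compound 1 to compound 3 (0.36 log units; beyond the scatter), a change of configuration alone, an 81-fold lower number from compound 1 to compound 4 (1.91 log units; beyond the scatter) shows that attaching the saturated ring through a different ring carbon, with both stereocentres redrawn, can move the number much further. Nothing measured here accounts for the size of these steps.

As far as these compounds go, compound 4 combines the new ring attachment with both redrawn stereocentres, so the share of each remains open. From the compounds shown here alone, whether an amine or a carboxylic acid in place of the hydroxyl group would keep the number of compound 4 also remains open.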